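The source may report more compounds than this note shows. Statements on the series, on what has been measured and on what is new or still open speak of the compounds shown alone.

Measured compounds:
- compound 1, `O=C(Nc1ccccc1F)C(Cl)Cl`: "not determined" (no result reported)
- compound 2, `Cc1cccc(NC(=O)C(Cl)Cl)c1`: "not determined" (no result reported)
- compound 3, `O=C(Nc1cccc(I)c1)C(Cl)Cl`: 58800 nM

All three compounds share one core, a dichloroacetamide attached to a benzene ring, and differ only in the group carried on that ring. For the measured compounds named here, in a functional assay on BGC-823 cells (Homo sapiens) for antiproliferative activity, read by MTT assay, with a stated time of 72 h (a higher number here means a weaker inhibitor, a lower number a stronger inhibitor), compound 1 and compound 2 have no result, so compound 3 stands alone: it gives the only number, 58800 nM, a concentration so high that it marks compound 3 as a weak inhibitor. Going by the values given here, nothing can be said about how the ring group shifts the number, since no two measured compounds can be compared.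

Compound 4, `O=C(Nc1cccc(C(F)(F)F)c1)C(Cl)Cl`, is the next candidate. The change from compound 3 is trifluoromethyl in place of iodo on an aromatic carbon. Among the compounds with values here, without any measured step to lean on, the expectation rests on the single value of compound 3 alone, and the expected step is a 1.0-fold higher number from compound 3 to compound 4 (0.01 log units; within the scatter), which is meant as no change beyond the scatter. Compound 4 is therefore estimated at 60000 nM, with a plausible range from 20000 nM to 180000 nM.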

Compound 4, half-maximal inhibitory concentration: 143000 nM
For compound 4 the middle estimate is 2.4-fold (0.38 log units) below the measured one; low and high end bracket the measured number.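

For the compounds shown here, this is the first comparison the series allows, and in this assay it shows that the group on this aromatic carbon matters, with a 2.4-fold higher number from compound 3 to compound 4 (0.39 log units; beyond the scatter) when trifluoromethyl replaces iodo. The step is modest but beyond the usual scatter, so the two groups are not interchangeable here, and of this pair iodo gives the stronger inhibitor. Nothing available explains the rise in the number, so it stands as an observation only.

As far as these compounds go, whether an amine, a carboxylic acid or a longer carbon chain on this same aromatic carbon would lower the number remains open. One pair also leaves open whether the swap from iodo to trifluoromethyl would have a similar effect elsewhere on the ring, or whether any group here could turn this weak inhibitor into a strong one.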